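The source may hold more compounds than are shown below. What is called first, only, known or untested is meant among the compounds shown, and "the series" means these compounds.

Measured compounds:
- compound 1, `COc1ccc(/C=N/NC(=O)c2cc(OC)c(OC)c(OC)c2)c(OC)c1`: 10%
- compound 2, `COc1cc(C2=NN(C(C)=O)C(c3cc(Cl)cc(Cl)c3)O2)cc(OC)c1OC`: 52.7%

Of the compounds shown here, two have been measured in a functional assay on PC-3 cells (Homo sapiens) for antiproliferative activity, read by MTT assay, tested at 1 uM; on this read-out lower numbers stand for a weaker effect and higher numbers for a stronger effect at the one concentration tested. Compound 1 `COc1ccc(/C=N/NC(=O)c2cc(OC)c(OC)c(OC)c2)c(OC)c1` gives 10% in this assay. Compound 2 `COc1cc(C2=NN(C(C)=O)C(c3cc(Cl)cc(Cl)c3)O2)cc(OC)c1OC` gives 52.7% in this assay. Compound 2 stands highest of the two numbers; its nearest neighbour is compound 1, and the gap between them is beyond the usual scatter of repeated measurements, so compound 2 is the stronger of the two at the single concentration tested.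

The step considered next leads from compound 2 to compound 3 `COc1cc(C2=NN(C(C)=O)C(c3ccc(Cl)c(Cl)c3)O2)cc(OC)c1OC`. The two have the same atoms joined differently: 3,4-dichlorophenyl in place of 3,5-dichlorophenyl on a saturated ring carbon

Going by the values given here, no step between two measured compounds is available to guide this change. The two chlorine atoms are merely rearranged on the same six-membered aromatic ring, while the rest of the structure, including the five-membered non-aromatic ring with 2 nitrogen and 1 oxygen and its acetyl group, is kept. The step expected from compound 2 to compound 3 in this assay is therefore small, a number 2.7 percentage points lower from compound 2 to compound 3 (within the scatter), not clearly beyond the scatter in either direction. Compound 3 is estimated at 50% in this assay, with a range from 25% to 75%.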

Compound 3, a percentage reported as inhibition, at one concentration (the size of the read-out at that concentration, not a potency): 28.1%
The estimate for compound 3 lay 21.9 percentage points above the measured number, within the range that was stated.
By their numbers in this assay, from the lowest: compound 1; then compound 3; then compound 2.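

The two chlorine atoms stay on the same ring and no atom is gained or lost, yet in this assay the change to 3,4-dichlorophenyl from 3,5-dichlorophenyl gives a number 24.6 percentage points lower from compound 2 to compound 3 (beyond the scatter) at this saturated ring carbon. The earlier compounds shown here could not show this, since no pair among them differed in one place, and it means that the arrangement of the chlorine atoms on this ring matters here, not merely their presence. Nothing measured on these compounds explains the drop, so the result records a difference without giving its cause.

This is a single pair at a single concentration, so it gives no potency and no general rule for how substituents on this ring behave. Open questions are how a plain phenyl ring, a 3,5-difluorophenyl or a 3,5-dimethoxyphenyl group would fare at this carbon, and whether a longer chain such as propanoyl in place of the acetyl group would keep the read-out of compound 2.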